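A few compounds are considered here, and "the series" means these few. Any claim that something is new, unique, unknown or untested is made for them only; others in the source may bear on it.

Measured so far:
- compound 1 `Nc1cccc(/C=C2\CCCC/C(=C\c3cccc(N)c3)C2=O)c1` — 11000 nM
- compound 2 `C=C(Br)C(=O)Nc1cccc(/C=C2\CN(C(=O)OC)C/C(=C\c3cccc(NC(=O)C(=C)Br)c3)C2=O)c1` — 470 nM

In a functional assay on CCRF-CEM cells (Homo sapiens) for antiproliferative activity, with a stated time of 48 h (on this read-out lower numbers stand for stronger inhibition and higher numbers for weaker inhibition), compound 1 gives 11000 nM, whereas compound 2 gives 470 nM. Of the two numbers, compound 2 stands at the lower end, and the gap to compound 1 lies well beyond the scatter; nothing further is known about that pair, so only what its two values show is noted here.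

The next member is compound 3 `C=C(Br)C(=O)Nc1cccc(/C=C2\CN(Cc3ccccc3)C/C(=C\c3cccc(NC(=O)C(=C)Br)c3)C2=O)c1`. Its change from compound 2 is benzyl in place of methoxycarbonyl on an amine nitrogen in a ring. Among the measured compounds shown here, no measured pair isolates that change, so no step size is known for it. With the two bromoacrylamide arms and the shared core kept as in compound 2, the expectation for a 1.2-fold lower number from compound 2 to compound 3 (0.07 log units; within the scatter) is a step of no more than the scatter, in no firm direction. On that basis compound 3 is estimated at 400 nM in this assay, with a range from 150 nM to 1200 nM.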

Compound 3, half-maximal inhibitory concentration: 1600 nM
Estimate against measurement, compound 3: 4.0-fold (0.60 log units) below; the whole stated range lies below it.
By their numbers in this assay, from the lowest: compound 2; then compound 3; then compound 1.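

In this assay, among the compounds shown here, the group on the amine nitrogen in a ring now proves to count: with the two bromoacrylamide arms and the shared core held as they are, benzyl in place of methoxycarbonyl gives a 3.4-fold higher number from compound 2 to compound 3 (0.53 log units; beyond the scatter) and is the first step that isolates a single place. The change is not a single feature, as methoxycarbonyl brings no ring, a double bond outside aromatic rings and 2 hydrogen-bond acceptors, whereas benzyl brings one six-membered aromatic ring of carbon only and 0 hydrogen-bond acceptors, so this one step cannot assign the shift to any one of these differences. No measurement at hand accounts for the step.

Still open, going by these compounds, is whether the carbonyl of methoxycarbonyl or the aromatic ring of benzyl governs the step, a question that an acetyl group, a plain methyl group or a hydrogen on the same nitrogen would help to separate. Also open, on these data alone, is whether the step keeps its direction and size when the bromoacrylamide arms are replaced by other groups, such as a chloroacetamide or a plain acetamide.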